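This account rests on a few compounds, and the source may have more. Where it says the series, first, only, none or still open, it means among the compounds named here.

Values in a functional assay on HepG2 cells (Homo sapiens) for cytotoxicity, read by MTT assay, with a stated time of 48 h; a higher number here means a weaker inhibitor, a lower number a stronger inhibitor:
- compound 1 `CCN(CC)Cc1cc(Cl)cc2c(=O)cc(-c3ccc([N+](=O)[O-])cc3)oc12`: 1190 nM
- compound 2 `CCN(CC)Cc1cc(Cl)cc2c(=O)cc(-c3ccccc3Cl)oc12`: 7940 nM

Compound 2 holds the higher of the two numbers. Compound 3 `O=c1cc(-c2ccccc2Cl)oc2c(Cn3ccnc3)cc(Cl)cc12` has not yet been measured. It differs from compound 2 by 1H-imidazol-1-yl in place of diethylamino on a saturated chain carbon bound to an aromatic carbon. Among the measured compounds shown here, the only measured step, a 6.7-fold higher number from compound 1 to compound 2 (0.82 log units; beyond the scatter), exchanges 2-chlorophenyl for 4-nitrophenyl on an aromatic carbon, so it indicates a possible size but no direction. For the measured compounds named here, no measured step covers this change. The expected step is a 1.3-fold higher number from compound 2 to compound 3 (0.10 log units; within the scatter), with no clear shift beyond the scatter as the central expectation. For compound 3 the estimated value is 10000 nM, with an expected range of 3000 nM to 35000 nM.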

Compound 3, half-maximal inhibitory concentration: 3270 nM
Compound 3: the middle estimate sits 3.1-fold (0.49 log units) above what was measured, and the stated range covers the measured number.
By their numbers in this assay, from the lowest: compound 1; then compound 3; then compound 2.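

In this assay the group on the saturated chain carbon bound to an aromatic carbon now has a reading of its own: 1H-imidazol-1-yl in place of diethylamino gives a 2.4-fold lower number from compound 2 to compound 3 (0.39 log units; beyond the scatter), with the 2-chlorophenyl group unchanged. Among the compounds shown here, the earlier pair varied only the aryl group, so this is the first sign that this position also moves the number. No available evidence accounts for this step. From the compounds shown here alone, whether the exchange reads the same with the 4-nitrophenyl group of compound 1 remains open. So does the reading for a morpholine or a piperidine at this position.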